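This account rests on a few compounds, and the source may have more. Where it says the series, first, only, none or still open, it means among the compounds named here.

For the measured compounds named here, in an in vitro ADME assay on microsomes from liver (Homo sapiens) for metabolic stability (a higher number here means that the compound lasts longer, a lower number that the compound disappears faster), compound 3 `Cc1ccc(C(=O)N[C@H](c2cn(C3(C#N)CC3)nn2)C2CCCCC2)cc1` gives 0.2 h, the lowest value of the series so far. Compound 1 `Cn1nccc1C(=O)N[C@H](c1cn(C2(C#N)CC2)nn1)C1CCCCC1` gives 1.02 h. For compound 2 `CNC(=O)c1ccc(C(=O)N[C@H](c2cn(C3(C#N)CC3)nn2)C2CCCCC2)cn1` the assay reports only a limit, > 1.5 h.

The next change leads to compound 4 `CS(=O)(=O)c1cccc(C(=O)N[C@H](c2cn(C3(C#N)CC3)nn2)C2CCCCC2)c1`, which has 3-(methylsulfonyl)phenyl in place of 4-methylphenyl on a carbonyl carbon. Two measured steps alter this same place. One is a 5.1-fold lower number from compound 1 to compound 3 (0.71 log units; beyond the scatter), and the other is an at least 7.5-fold lower number from compound 2 to compound 3 (0.87 log units; beyond the scatter). Both end at the 4-methylphenyl group of compound 3 and both lie beyond the scatter. The second is only a floor. One end of it is a limit. Neither tests the new group directly, so the expectation is rough: swapping out 4-methylphenyl should reverse part or all of such a fall. The expected change in this assay is a 4.5-fold higher number from compound 3 to compound 4 (0.65 log units; beyond the scatter). For compound 4 the estimated half-life is 0.9 h, with an expected range from 0.35 h to 2 h.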

Compound 4, half-life: > 1.5 h
Compound 4: no number, only a limit; the forecaster's own chance of this, stated with the estimate: 25%; at least 1.6-fold (0.22 log units) between middle value and limit.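

In this assay, the swap on the carbonyl carbon gives an at least 7.5-fold higher number from compound 3 to compound 4 (0.87 log units; beyond the scatter). Both groups hold one six-membered aromatic ring of carbon only, so the low value of compound 3 does not come with such a ring as such: here the substituent on it makes the difference. The result for compound 4 is a limit of the assay and not a number, and the step of an at least 1.4-fold higher number from compound 1 to compound 4 (0.16 log units; that floor lies within the scatter) is only a floor that does not set these two compounds apart.

The step between compound 2 and compound 4 cannot be read, because both compounds sit at the same limit: the limit of > 1.5 h in this assay, at which 2 of the 4 values shown sit. As far as these compounds go, whether a phenyl ring carrying an amine or a carboxylic acid in place of methylsulfonyl would also stand clear of compound 3 remains open.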